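Chloro to methyl swap on the shared core, cytotoxicity notes

This account rests on a few compounds, and the source may have more. Where it says the series, first, only, none or still open, it means among the compounds named here.

Measured so far:
compound 1 `O=c1[nH]c2ccc(Cl)cc2n1Cc1c(F)cccc1F` — a limit, not a number: > 424000 nM
compound 2 `O=c1[nH]c2ccc(Cl)cc2n1S(=O)(=O)c1cc(F)cc(F)c1` — 202000 nM
compound 3 `Cc1ccc2[nH]c(=O)n(Cc3c(F)cccc3F)c2c1` — 236000 nM

In an ADME assay on MT4 cells (Homo sapiens) for cytotoxicity (a higher number here means that more compound is tolerated, a lower number that less compound is tolerated), compound 1 reaches only a limit of the assay, > 424000 nM. Compound 3 gives 236000 nM, and compound 2 gives 202000 nM; these two values lie within the scatter of each other. How the cores of compound 2 and compound 1 differ is not broken down here.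

For the measured compounds named here, the one counted step, (methyl in place of chloro on an aromatic carbon), gives an at least 1.7-fold lower number from compound 1 to compound 3 (0.25 log units; that floor lies within the scatter); only a floor can be stated for it because of the limit of > 424000 nM in this assay, at which 1 of the 3 values shown sits.

Compound 4 `Cc1ccc2[nH]c(=O)n(S(=O)(=O)c3cc(F)cc(F)c3)c2c1` is not yet measured. It differs from compound 2 by methyl in place of chloro on an aromatic carbon, the same change as that from compound 1 to compound 3, the place being the same word for word.

Given that the measured step from compound 1 to compound 3 rests on a limit and its floor lies within the scatter, the step from compound 2 to compound 4 is expected to be small, about a 1.1-fold lower number from compound 2 to compound 4 (0.05 log units; within the scatter). Compound 4 is estimated at 180000 nM, expected between 90000 nM and 400000 nM.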

Compound 4, half-maximal cytotoxic concentration: 23400 nM
For compound 4 the middle estimate is 7.7-fold (0.89 log units) above the measured one, and the stated range ends above it.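

In this assay, methyl in place of chloro on an aromatic carbon gives an 8.6-fold lower number from compound 2 to compound 4 (0.94 log units; beyond the scatter), so on the core of compound 2 this change carries a step beyond the scatter. Whether that step differs from the one on the core of compound 1 remains unsettled, so the series shows neither that the change transfers unaltered nor that its size depends on the core: the same change on two cores in this assay, an at least 1.7-fold lower number (0.25 log units; that floor lies within the scatter) from compound 1 to compound 3 and an 8.6-fold lower number (0.94 log units; beyond the scatter) from compound 2 to compound 4; the limit leaves it open whether they differ The earlier step can be given only as a floor, and the comparison stays open because of the limit reached by compound 1: the limit of > 424000 nM in this assay, at which 1 of the 4 values shown sits.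

Open, as far as these compounds go, is whether a third group on that aromatic carbon, such as fluoro, methoxy or an amine, would track methyl or chloro on either core. With one matched pair per core, the compounds shown also leave open how the same swap would behave on any further core, and whether the large step on the core of compound 2 is a general feature or specific to that pair.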